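From Benzyl to 4-Methoxyphenyl on a Shared Core

This account rests on a few compounds, and the source may have more. Where it says the series, first, only, none or still open, it means among the compounds named here.

Compound 2 `C=C(Br)C(=O)Nc1cccc(-c2cn3nc(CCc4ccccc4)sc3n2)c1` gives 3300 nM in a functional assay on HeLa cells (Homo sapiens) for inhibition, read by cell counting, with a stated time of 4 days; on this read-out higher numbers stand for weaker inhibition and lower numbers for stronger inhibition. For the measured compounds named here, it is one of only two measured compounds; the other, compound 1 `C=C(Br)C(=O)Nc1cccc(-c2cn3nc(Cc4cccc(OC)c4)sc3n2)c1`, gives 2500 nM in this assay, and the two values lie within the scatter of each other, so neither can be placed above the other. Compound 3 `C=C(Br)C(=O)Nc1cccc(-c2cn3nc(Cc4ccc(OC)cc4)sc3n2)c1` differs from compound 2 in one place (4-methoxyphenyl in place of benzyl on a saturated chain carbon bound to an aromatic carbon). Going by the values given here, the only measured step that bears on this change is a 1.3-fold higher number from compound 1 to compound 2 (0.12 log units; within the scatter), which swaps related groups on the same saturated chain carbon and stays within the scatter. Among the compounds with values here, no measured pair shows the entering 4-methoxyphenyl group itself, so nothing suggests this change should weigh more. The expected step of a 1.2-fold lower number from compound 2 to compound 3 (0.07 log units; within the scatter) is therefore small, leaning if anything toward a lower number, guided by compound 1 with 2500 nM. Compound 3 is estimated at 2800 nM, with a range from 1200 nM to 6500 nM.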

Compound 3, half-maximal inhibitory concentration: 2300 nM
For compound 3 the middle estimate is 1.2-fold (0.09 log units) above the measured one, within the range that was stated.
By their numbers in this assay, from the lowest: compounds 3, 1 and 2 (each within the scatter of the next).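

In this assay, putting 4-methoxyphenyl in place of benzyl on a saturated chain carbon bound to an aromatic carbon gives a 1.4-fold lower number from compound 2 to compound 3 (0.16 log units; within the scatter), so adding this methoxy-bearing group does not clearly separate the two compounds. Exchanging 3-methoxyphenyl for 4-methoxyphenyl at the same place gives a 1.1-fold lower number from compound 1 to compound 3 (0.04 log units; within the scatter), so these two placements of the methoxy group on the ring cannot be told apart on this read-out. No measurement at hand offers an explanation for how closely these values lie.

Going by these compounds, all three groups here carry a six-membered aromatic ring of carbon only, so it remains open whether an amine, a carboxylic acid or a longer chain at this place would give a step beyond the scatter. The shared core is also unchanged throughout, leaving open how changes elsewhere in the molecule would read.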